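The compounds below may be only part of what the source reports. "The series", "measured", "known", "first", "only" and "open" are said of these compounds alone.

Working notes on the series. Compound 1, `COc1cc(-c2cc(/C=C/C(=O)c3ccc(Cl)c(Cl)c3)[nH]n2)cc(OC)c1OC`, is tested in a functional assay on NCI-H23 cells (Homo sapiens) for inhibition, read by sulforhodamine B assay, with a stated time of 48 h (a lower number here means that less compound is tolerated, a higher number that more compound is tolerated), and returns > 100000 nM, a limit of the assay and not a number. Among the measured compounds shown here, compound 2, `COc1ccc(C(=O)/C=C/c2cc(-c3cc(OC)c(OC)c(OC)c3)n[nH]2)cc1OC`, gives 22700 nM in this assay; this is the only number in hand for the series, the one further value being (the limit of > 100000 nM in this assay, at which 1 of the 2 values shown sits). For the measured compounds named here, the single measured step, an at least 4.4-fold lower number from compound 1 to compound 2 (0.64 log units; beyond the scatter), runs from the dichloro compound to the dimethoxy compound.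

Compound 3, `COc1cc(C(=O)/C=C/c2cc(-c3cc(OC)c(OC)c(OC)c3)n[nH]2)cc(OC)c1OC`, is not yet measured. It differs from compound 2 by methoxy in place of hydrogen on an aromatic carbon, so that the ring on the carbonyl carbon carries three methoxy groups instead of two. Going by the values given here, no measured step covers a methoxy added for a hydrogen; the one step available concerns a different exchange on the same ring and offers no direct guidance on this one. A change within the scatter, or a small shift toward a lower number in this assay, is the expectation. For compound 3 the estimated value in this assay is 15000 nM, within 5000 nM to 50000 nM, which is expected to mean a 1.5-fold lower number from compound 2 to compound 3 (0.18 log units; within the scatter).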

Compound 3, concentration lethal to 50% of the cells: 64300 nM
Compound 3: the middle estimate sits 4.3-fold (0.63 log units) below what was measured, and the stated range ends below it.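

In this assay, methoxy in place of hydrogen on the aromatic carbon, ortho to a methoxy group on the ring on the carbonyl carbon, gives a 2.8-fold higher number from compound 2 to compound 3 (0.45 log units; beyond the scatter) and so shows that this position is not indifferent to substitution, and that the added group moves the number toward more compound being tolerated. The earlier step showed only a lower number on exchanging 3,4-dichlorophenyl for 3,4-dimethoxyphenyl; with the third methoxy the direction turns, so across the three compounds the number does not fall steadily as methoxy groups are added to this ring, and compound 2 holds the lowest number shown. The top of the range remains a limit and not a number, held by compound 1: the limit of > 100000 nM in this assay, at which 1 of the 3 values shown sits.

No measured property in hand accounts for the step, and it remains unclear whether it belongs to methoxy in particular or to any group at this place. Going by these compounds, whether a hydroxyl, an amine or a longer chain such as ethoxy at this position would move the number the same way stays open.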